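The source may hold more compounds than are shown below. What is called first, only, known or untested is meant among the compounds shown, and "the series" means these compounds.

In an ADME assay on MT4 cells (Homo sapiens) for cytotoxicity, read by MTT assay, with a stated time of 96 h (on this read-out lower numbers stand for higher toxicity in this test and higher numbers for lower toxicity in this test), compound 1 `Cc1ccc(C2CC(c3ccccc3)=NN2c2ccc(S(N)(=O)=O)cc2)cc1` gives 40000 nM and compound 2 `Cc1cccc(C2CC(c3ccc(Oc4ccccc4)cc3)=NN2c2ccc(S(N)(=O)=O)cc2)c1` gives 35000 nM. These two numbers lie within the usual scatter of each other, so compound 2 stands level with compound 1. Compound 3 `Cc1cccc(C2CC(c3ccccc3)=NN2c2ccc(S(N)(=O)=O)cc2)c1` differs from compound 2 in one place: hydrogen in place of phenoxy on an aromatic carbon, with hydrogen in place of phenoxy on an aromatic carbon. Among the measured compounds shown here, no measured pair shows this change alone, so the expectation rests on those two close values. The expected change, a 1.1-fold higher number from compound 2 to compound 3 (0.06 log units; within the scatter), is none beyond the scatter. For compound 3 the estimate is 40000 nM, with an expected range of 18000 nM to 90000 nM.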

Compound 3, half-maximal cytotoxic concentration: 37000 nM
Estimate against measurement, compound 3: 1.1-fold (0.03 log units) above, and the stated range covers the measured number.
By their numbers in this assay, from the lowest: compounds 2, 3 and 1 (each within the scatter of the next).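

In this assay, replacing phenoxy with hydrogen on the aromatic carbon gives a 1.1-fold higher number from compound 2 to compound 3 (0.02 log units; within the scatter), so this large group has no readable effect on the number here. Putting 3-methylphenyl in place of 4-methylphenyl on the saturated ring carbon likewise gives a 1.1-fold lower number from compound 1 to compound 3 (0.03 log units; within the scatter), which also cannot be told apart from no effect. No measurement shown gives a reason for either result. Still open, from the compounds shown here alone, is whether an amine or a carboxylic acid on that aromatic carbon would move the number beyond the usual scatter.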